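Adding Methyls Back to the Piperazine of Compound 3

The source may hold more compounds than are shown below. What is called first, only, known or untested is meant among the compounds shown, and "the series" means these compounds.

Compound 3 `CN(C[C@H]1Cc2c(cccc2N2CCNCC2)CN1)[C@H]1CCCc2cccnc21` is the weakest of the three measured compounds in an ADME assay on microsomes from liver (Mus musculus) for metabolic stability, read by LC-MS, with a stated time of 10 min; a lower number here means that less of the compound is left, a higher number that more of the compound is left: compound 3 gives 19.9%. Compound 1 `C[C@@H]1CN(c2cccc3c2C[C@H](CN(C)[C@H]2CCCc4cccnc42)NC3)C[C@H](C)N1` gives 85.6%, and compound 2 `c1cnc2c(c1)CCC[C@@H]2N(CC1CCCCC1)C[C@H]1Cc2c(cccc2N2CCNCC2)CN1` gives 85.6%; the two values lie within the scatter of each other. The change from compound 1 to compound 3 was a number 65.7 percentage points lower from compound 1 to compound 3 (beyond the scatter), and the change from compound 2 to compound 3 was a number 65.7 percentage points lower from compound 2 to compound 3 (beyond the scatter).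

Compound 4 `C[C@@H]1CN(c2cccc3c2C[C@H](CN(C)[C@H]2CCCc4cccnc42)NC3)C[C@H](C)N1C` differs from compound 3 in one place: 3,4,5-trimethylpiperazin-1-yl in place of piperazin-1-yl on an aromatic carbon. Among the compounds with values here, of the two measured steps, the one from compound 1 to compound 3 bears most directly on this, since it removed the 3,5-dimethylpiperazin-1-yl group from the same aromatic carbon and the result was a large drop; compound 4 restores that group with one more methyl. The step from compound 2 to compound 3 also shows that a large rise is possible from compound 3. Compound 4 is therefore expected to move upward by a large step, a number 60.1 percentage points higher from compound 3 to compound 4 (beyond the scatter), because of the size of a number 65.7 percentage points lower from compound 1 to compound 3 (beyond the scatter). Compound 4 is estimated at 80%, with a range from 55% to 95%.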

Compound 4, percent of the compound remaining: 39.6%
Estimate against measurement, compound 4: 40.4 percentage points above; the whole stated range lies above it.
By their numbers in this assay, from the lowest: compound 3; then compound 4; then compounds 1 and 2 (each within the scatter of the next).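

In this assay, within the data shown here, the only difference between compound 1 and compound 4 is a methyl in place of hydrogen on the amine nitrogen in the ring, and this single change gave a number 46 percentage points lower from compound 1 to compound 4 (beyond the scatter), so substitution on that nitrogen matters on its own and a return to the carbon methyls of compound 1 does not by itself restore its number. The 3,4,5-trimethylpiperazin-1-yl group on the aromatic carbon still retains part of the gain over piperazin-1-yl, as a number 19.7 percentage points higher from compound 3 to compound 4 (beyond the scatter) shows, which puts compound 4 at a level of its own, separate from both the unsubstituted piperazine of compound 3 and the 3,5-dimethylpiperazin-1-yl group of compound 1. No measured information here accounts for the effect of the added methyl on the ring nitrogen.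

The compounds shown leave open whether the loss seen with the methyl is particular to that group or would also appear with an ethyl or an acetyl on the same nitrogen. They also leave open how a piperazine bearing a single carbon methyl, or a morpholine in the same place, would compare.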